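This account rests on a few compounds, and the source may have more. Where it says the series, first, only, none or still open, it means among the compounds named here.

Measured compounds:
Compound 1 `Fc1ccc(Cl)c(-c2cc(-c3cnn(C4CCNCC4)c3)on2)c1`: 270 nM
Compound 2 `Fc1cccc(-c2cc(-c3cnn(C4CCNCC4)c3)on2)c1Cl`: 230 nM

In an assay on isolated protein for positive allosteric modulation of Neuronal acetylcholine receptor; alpha4/beta2 (Homo sapiens) (on this read-out lower numbers stand for an effect already at smaller amounts and higher numbers for an effect only at larger amounts of compound), compound 1 gives 270 nM and compound 2 gives 230 nM; the step of a 1.2-fold lower number from compound 1 to compound 2 (0.07 log units; within the scatter) leaves the two indistinguishable, so compound 2 cannot be set apart from compound 1 on these numbers.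

Compound 3 `Clc1sccc1-c1cc(-c2cnn(C3CCNCC3)c2)on1` has not yet been measured. It differs from compound 2 by 2-chlorothiophen-3-yl in place of 2-chloro-3-fluorophenyl on an aromatic carbon. Among the measured compounds shown here, the only measured step, a 1.2-fold lower number from compound 1 to compound 2 (0.07 log units; within the scatter), moves a fluorine within the same six-membered ring and says nothing about exchanging that ring for a five-membered one bearing sulfur. For the measured compounds named here, no measured step therefore bears directly on this change, and the expectation can only start from the value of compound 2 with a wide margin.

Compound 3 is estimated at 300 nM, within 120 nM to 800 nM, which would mean an expected step of a 1.3-fold higher number from compound 2 to compound 3 (0.12 log units; within the scatter).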

Compound 3, half-maximal effective concentration: 130 nM
Beside the measured number, compound 3's estimate is 2.3-fold (0.36 log units) above it; measured number inside the range.
By their numbers in this assay, from the lowest: compounds 3, 2 and 1 (each within the scatter of the next, the first and the last beyond it).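

Replacing the 2-chloro-3-fluorophenyl with 2-chlorothiophen-3-yl on this aromatic carbon shows that the position accepts a five-membered aromatic ring with a sulfur atom, whereas the earlier pair only moved a fluorine within one six-membered ring. In this assay the exchange stays within the scatter against one phenyl compound (a 1.8-fold lower number from compound 2 to compound 3 (0.25 log units; within the scatter)) and is a modest step beyond it against the other (a 2.1-fold lower number from compound 1 to compound 3 (0.32 log units; beyond the scatter)), so compound 3 cannot be set apart from compound 2 but does separate from compound 1. No measurement is available that would explain this result.

The compounds shown leave open whether the chlorine of the 2-chlorothiophen-3-yl group can give way to a methyl group or to hydrogen. They also leave open how a methoxy group on that ring would read in this assay.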